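The source may report more compounds than this note shows. Statements on the series, on what has been measured and on what is new or still open speak of the compounds shown alone.

Compound 1 `CCN(CC)S(=O)(=O)c1ccc(S(=O)(=O)N2CCC[C@@H](C(=O)NC3CN(C(=O)OC(C)(C)C)C3)C2)cc1` and compound 2 `CC(C)c1noc(N2CCN(C(=O)[C@@H]3CCCN(S(=O)(=O)c4ccc(S(=O)(=O)C(C)C)cc4)C3)CC2)n1` share a core and were both tested in a functional assay on MIA PaCa-2 cells (Homo sapiens) for inhibition, read by MTT assay, with a stated time of 7 days; on this read-out lower numbers stand for stronger inhibition and higher numbers for weaker inhibition. Compound 1 gives 200 nM, while compound 2 gives 70 nM, the lower of the two numbers and a gap beyond the usual scatter. Compound 3 `CC(C)NS(=O)(=O)c1ccc(S(=O)(=O)N2CCC[C@@H](C(=O)N3CCN(c4nc(C(C)C)no4)CC3)C2)cc1` is a close relative of compound 2, with isopropylamino in place of isopropyl on a sulfonyl sulfur. For the measured compounds named here, no measured pair shows the effect of this exact change, so only a modest step is expected, in either direction: the step from compound 2 to compound 3 is estimated at a 1.4-fold higher number from compound 2 to compound 3 (0.15 log units; within the scatter). Compound 3 is therefore expected at 100 nM, between 35 nM and 300 nM.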

Compound 3, half-maximal inhibitory concentration: 2600 nM
For compound 3 the middle estimate is 26-fold (1.41 log units) below the measured one, and the stated range ends below it.
By their numbers in this assay, from the lowest: compound 2; then compound 1; then compound 3.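

In this assay the swap of isopropyl for isopropylamino on a sulfonyl sulfur gives a 37-fold higher number from compound 2 to compound 3 (1.57 log units; beyond the scatter) and so shows that this position is far from indifferent to a small change. One added nitrogen, carrying one hydrogen-bond donor, is the whole difference between these two compounds. No measurement shown here accounts for the loss. Still open, as far as these compounds go, is whether the nitrogen itself or its hydrogen matters. A dimethylamino group on the same sulfur, with nitrogen but no such hydrogen, would help separate the two.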